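The compounds below may be only part of what the source reports. "The series", "measured", "known", "first", "only" and "open" are said of these compounds alone.

Working notes on the series, tested in a functional assay on HeLa cells (Homo sapiens) for cytotoxicity, read by sulforhodamine B assay, with a stated time of 48 h; a higher number here means a weaker inhibitor, a lower number a stronger inhibitor:

Compound 1 `O=C(c1cccnc1)c1cc(F)ccc1O`: 27000 nM
Compound 2 `C=CCOc1ccc(C)cc1C(=O)c1cccnc1`: 94000 nM

Of these two numbers, compound 2 holds the higher one at 94000 nM, and the gap to compound 1 lies beyond the usual scatter. Both values are weak in this assay.

Compound 3 `Cc1ccc(O)c(C(=O)c2cccnc2)c1` is the next to be read. It departs from compound 2 by one change: hydrogen in place of allyl on an oxygen on an aromatic ring, which is hydrogen in place of allyl on an oxygen on an aromatic ring, or allyloxy to hydroxy.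

Going by the values given here, no measured pair isolates this change, so its size is a judgement. Compound 1, which also carries a hydroxy, gives 27000 nM, and this points to a lower number for compound 3. The expected step of a 2.7-fold lower number from compound 2 to compound 3 (0.43 log units; beyond the scatter) is modest but beyond the scatter. Compound 3 is estimated at 35000 nM, with an expected range of 13000 nM to 85000 nM.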

Compound 3, half-maximal inhibitory concentration: 26000 nM
The estimate for compound 3 lay 1.3-fold (0.13 log units) above the measured number; measured number inside the range.
By their numbers in this assay, from the lowest: compounds 3 and 1 (each within the scatter of the next); then compound 2.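

Allyloxy to hydroxy now has a measured pair: in this assay the change gives a 3.6-fold lower number from compound 2 to compound 3 (0.56 log units; beyond the scatter), so on this oxygen the allyl group goes with the higher number and the hydrogen with the lower. Methyl in place of fluoro on an aromatic carbon gives a 1.0-fold lower number from compound 1 to compound 3 (0.02 log units; within the scatter), so this swap produces no distinguishable change, and the two hydroxy compounds, compound 1 and compound 3, stand together apart from compound 2. No accompanying measurement explains the allyl step.

The compounds shown leave open whether a methoxy or a longer chain on the oxygen would read like compound 2 or like compound 3. They also leave open whether an amine or a carboxylic acid on that aromatic carbon would depart from methyl and fluoro.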